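Working notes on compound 4 in the agonist read-out

This account rests on a few compounds, and the source may have more. Where it says the series, first, only, none or still open, it means among the compounds named here.

Compound 1 `c1ccc2c(c1)CN[C@@H](CN(CCCCNCc1ccncc1)[C@H]1CCCc3cccnc31)C2`, compound 2 `CC(C)(CCN)CN(C[C@H]1Cc2ccccc2CN1)[C@H]1CCCc2cccnc21` and compound 3 `C(=C/CN(C[C@H]1Cc2ccccc2CN1)[C@H]1CCCc2cccnc21)\CNCC1CCOCC1` share one core and differ only in the group on a saturated chain carbon bound to an amine nitrogen. In a functional assay on cells for agonist activity at C-X-C chemokine receptor type 4 (Homo sapiens), read by fluorescence and calcium flux, with a stated time of 90 s (on this read-out lower numbers stand for an effect already at smaller amounts and higher numbers for an effect only at larger amounts of compound), compound 1 gives > 30000 nM, a limit of the assay and not a number. In this assay compound 2 gives > 30000 nM, again a limit. In this assay compound 3 gives > 30000 nM, also a limit. Consequently a step that the two limits leave unreadable from compound 1 to compound 2, a step that the two limits leave unreadable from compound 1 to compound 3 and a step that the two limits leave unreadable from compound 2 to compound 3 carry no readable size; what unites them is the limit of > 30000 nM in this assay, at which 3 of the 3 values shown sit. Compound 4 `C(=C/CN(C[C@H]1Cc2ccccc2CN1)[C@H]1CCCc2cccnc21)\CNCc1ccccn1` carries pyridin-2-yl in place of oxan-4-yl on a saturated chain carbon bound to an amine nitrogen. Going by the values given here, no measured step bears readably on this change. Compound 4 is therefore expected at 40000 nM (8000 nM to 200000 nM), most probably reported as a limit once more. The expected step that the limit leaves unreadable from compound 3 to compound 4 is accordingly none beyond the scatter.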

Compound 4, half-maximal effective concentration: > 30000 nM
Compound 4 gave a limit, no number; the forecaster's own chance of this, stated with the estimate: 85%; the middle value is on the limit's open side.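

No step can be read between compound 4 and compound 1, compound 2 or compound 3, as each value is a limit and not a number: the limit of > 30000 nM in this assay, at which 4 of the 4 values shown sit.

The compounds shown leave open which group, if any, gives a measurable value in this assay.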